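Pyrazole exchange on the fused core: microsomal clearance of compound 4

The source may report more compounds than this note shows. Statements on the series, on what has been measured and on what is new or still open speak of the compounds shown alone.

Measured so far in an ADME assay on microsomes from liver (Homo sapiens) for metabolic stability, read by LC-MS, using NADPH, with stated times of 5 min and 30 min, tested at 1 uM; on this read-out lower numbers stand for slow clearance and higher numbers for fast clearance:
- compound 1 `Cn1nccc1-c1cnc(NCc2c(F)ccc3c2CCO3)c2cn[nH]c(=O)c12` gives 14 mL.min-1.g-1 
- compound 2 `CN(C(=O)c1ccccc1)c1cnc(NCc2c(F)ccc3c2CCO3)n2cnnc12` gives > 300 mL.min-1.g-1, a limit of this assay
- compound 3 `O=C1CCCN1c1cnc(NCc2c(F)ccc3c2CCO3)n2cnnc12` gives < 3 mL.min-1.g-1, a limit of this assay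

Going by the values given here, compound 1 is the only member with a number rather than a limit, so it is the sole anchor for this assay. The limits of compound 2 and compound 3 sit at opposite ends of the range, as shown by the limit of > 300 mL.min-1.g-1 in this assay, at which 1 of the 3 values shown sits, and (the limit of < 3 mL.min-1.g-1 in this assay, at which 1 of the 3 values shown sits); they are joined by the step of an at least 100-fold lower number from compound 2 to compound 3 (2.00 log units; beyond the scatter), but that change sits on a different core and replaces a different kind of group, so it does not bear on the change to compound 4.

Compound 4 `Cc1nn(C)cc1-c1cnc(NCc2c(F)ccc3c2CCO3)c2cn[nH]c(=O)c12` differs from compound 1 only in the pyrazole, (1,3-dimethyl-1H-pyrazol-4-yl in place of 1-methyl-1H-pyrazol-5-yl on an aromatic carbon). Among the compounds with values here, no measured pair shows an exchange of this kind, so no direction can be drawn from the series. The expectation for this assay is therefore a step within the scatter, a 1.1-fold higher number from compound 1 to compound 4 (0.03 log units; within the scatter). Compound 4 is expected at 15 mL.min-1.g-1, within 6 mL.min-1.g-1 to 40 mL.min-1.g-1.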

Compound 4, intrinsic clearance in microsomes: 27 mL.min-1.g-1
For compound 4 the middle estimate is 1.8-fold (0.26 log units) below the measured one, and the stated range covers the measured number.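

Going by these compounds alone, compound 1 and compound 4 form the first pair on this core that differs in one place: in this assay, 1,3-dimethyl-1H-pyrazol-4-yl in place of 1-methyl-1H-pyrazol-5-yl gives a 1.9-fold higher number from compound 1 to compound 4 (0.29 log units; within the scatter). At this aromatic carbon, para to a large group, the two pyrazoles therefore cannot be told apart on this read-out, although they differ in both the ring atom that carries the bond and the methyl groups. Nothing at hand gives a reason for this step.

A single pair does not show whether an amine, a carboxylic acid or a phenyl ring on this carbon would give a number close to that of compound 1. Also open, on these data alone, is the effect of a longer chain in place of either methyl of the 1,3-dimethyl-1H-pyrazol-4-yl group.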